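Rearranging the lactam ring of a cytotoxic butenolide

This account rests on a few compounds, and the source may have more. Where it says the series, first, only, none or still open, it means among the compounds named here.

Of the compounds shown here, three have been measured in a functional assay on HCT-15 cells (Homo sapiens) for cytotoxicity; on this read-out higher numbers stand for an effect only at larger amounts of compound and lower numbers for an effect already at smaller amounts. Compound 1 `CC1=C(O)[C@H](C/C(C)=C\CC[C@H](C)/C=C/C=C(\C)CCCC2=CCN(CCC(C)C)C2=O)OC1=O` gives 5 ug/mL, compound 2 `CCC(C)CN1CC=C(CCC/C(C)=C/C=C/[C@@H](C)CC/C=C(/C)C[C@@H]2OC(=O)C(C)=C2O)C1=O` gives 5.3 ug/mL, and compound 3 `CCC(C)CN1CC=C(CCC/C(C)=C/C=C/[C@@H](C)CC/C=C(/C)C[C@H]2OC(=O)C(C)=C2O)C1=O` gives 22.3 ug/mL. Among these three numbers compound 2 stands second highest; its nearest neighbour is compound 1, and the furthest is compound 3. The step of a 1.1-fold higher number from compound 1 to compound 2 (0.03 log units; within the scatter) changes only the chain on the ring nitrogen and stays within the scatter. The step of a 4.2-fold higher number from compound 2 to compound 3 (0.62 log units; beyond the scatter) is the only one here that goes beyond the scatter, and it comes with the fact that one of compounds 2 and 3 is drawn with a defined configuration and the other without, at the place where they differ.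

Compound 4 `CC1=C(O)[C@H](C/C(C)=C\CC[C@H](C)/C=C/C=C(\C)CCCC2=CC(=O)N(CCC(C)C)C2)OC1=O` is not yet measured. Compared with compound 2 it shows (a group of 11 heavy atoms (9 carbon, 1 nitrogen, 1 oxygen; one five-membered non-aromatic ring with 1 hetero atom) in place of a group of 11 heavy atoms (9 carbon, 1 nitrogen, 1 oxygen; one five-membered non-aromatic ring with 1 hetero atom), on a saturated chain carbon, three bonds along the chain from a double-bonded chain carbon). Neither measured step touches this part of the molecule: the step from compound 1 to compound 2 alters the chain on the nitrogen and the step from compound 2 to compound 3 alters a stereocentre on the core. Going by the values given here, the one change already seen at the ring nitrogen left the number unmoved, so for compound 4 a step in this assay of no more than modest size, in no firm direction, is expected, as a 1.3-fold higher number from compound 2 to compound 4 (0.12 log units; within the scatter). Compound 4 is accordingly estimated at 7 ug/mL, within a range from 3 ug/mL to 18 ug/mL.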

Compound 4, concentration for half-maximal effect: 21.6 ug/mL
For compound 4 the middle estimate is 3.1-fold (0.49 log units) below the measured one; measured number outside the range, above it.
By their numbers in this assay, from the lowest: compounds 1 and 2 (each within the scatter of the next); then compounds 4 and 3 (each within the scatter of the next).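

Among these compounds, the group on the saturated chain carbon, three bonds along the chain from a double-bonded chain carbon, is changed only here, and the two groups have the same atoms, joined differently. In this assay this rearrangement alone moves the number beyond the scatter, with a 4.3-fold higher number from compound 1 to compound 4 (0.64 log units; beyond the scatter) and a 4.1-fold higher number from compound 2 to compound 4 (0.61 log units; beyond the scatter), whereas the swap of isobutyl for sec-butyl on the ring nitrogen gave only a 1.1-fold higher number from compound 1 to compound 2 (0.03 log units; within the scatter), so in this small set the way the ring atoms are joined counts for more than that change of the nitrogen chain. Going by these compounds alone, nothing given here accounts for this loss, as the only supporting information concerns a stereocentre elsewhere on the molecule.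

The compounds shown leave open whether the rearranged ring would respond to sec-butyl on its nitrogen as the original ring does, and whether a longer chain such as n-hexyl would change the number on either ring. They also leave open how a six-membered piperidinone ring, or a pyrrolidine ring with no carbonyl at all, would fare in this position.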